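Swapping the aryl group on a shared core

The source may hold more compounds than are shown below. What is called first, only, known or untested is meant among the compounds shown, and "the series" means these compounds.

In a functional assay on A549 cells (Homo sapiens) for cytotoxicity, read by MTT assay, with a stated time of 48 h (on this read-out lower numbers stand for stronger inhibition and higher numbers for weaker inhibition), compound 3 (`CC(C)(C)c1ccc(/C=C/[C@](C)(O)CC[C@@H]2[C@@]3(C)CCCC(C)(C)[C@@H]3CC[C@@]2(C)O)cc1`) gives 45000 nM, level with compound 2 (`COc1cccc(OC)c1/C=C/[C@](C)(O)CC[C@@H]1[C@@]2(C)CCCC(C)(C)[C@@H]2CC[C@@]1(C)O`) at 42000 nM and well above compound 1 (`Cc1ccc(C)c(/C=C/[C@](C)(O)CC[C@@H]2[C@@]3(C)CCCC(C)(C)[C@@H]3CC[C@@]2(C)O)c1`) at 3320 nM. Compound 4 (`COc1cccc(/C=C/[C@](C)(O)CC[C@@H]2[C@@]3(C)CCCC(C)(C)[C@@H]3CC[C@@]2(C)O)c1OC`) differs from compound 3 in one group: 2,3-dimethoxyphenyl in place of 4-(tert-butyl)phenyl on a double-bonded chain carbon bound to a double-bonded chain carbon. The measured steps of a 13-fold higher number from compound 1 to compound 2 (1.10 log units; beyond the scatter) and a 14-fold higher number from compound 1 to compound 3 (1.13 log units; beyond the scatter) are large, but both start from the 2,5-dimethylphenyl group. The step that bears most closely is a 1.1-fold higher number from compound 2 to compound 3 (0.03 log units; within the scatter), which links 2,6-dimethoxyphenyl with 4-(tert-butyl)phenyl. Among the compounds with values here, no measured compound carries 2,3-dimethoxyphenyl, so no step beyond the scatter is expected. The expected change is a 1.5-fold lower number from compound 3 to compound 4 (0.18 log units; within the scatter). Compound 4 is estimated at 30000 nM, within an expected range of 9000 nM to 70000 nM.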

Compound 4, half-maximal inhibitory concentration: 3280 nM
Compound 4: the middle estimate sits 9.1-fold (0.96 log units) above what was measured; the measured number lies below the stated range.
By their numbers in this assay, from the lowest: compounds 4 and 1 (each within the scatter of the next); then compounds 2 and 3 (each within the scatter of the next).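

Changing 2,6-dimethoxyphenyl to 2,3-dimethoxyphenyl alone gives a 13-fold lower number from compound 2 to compound 4 (1.11 log units; beyond the scatter) and so shows that these two dimethoxyphenyl groups are not interchangeable on this chain carbon. The change from 4-(tert-butyl)phenyl gives a 14-fold lower number from compound 3 to compound 4 (1.14 log units; beyond the scatter) while a 1.0-fold lower number from compound 1 to compound 4 (0.01 log units; within the scatter) puts 2,3-dimethoxyphenyl level with 2,5-dimethylphenyl, so the lower pair of numbers is no longer held by compound 1 alone and includes a group with oxygen and one without. No evidence is available here to explain these differences.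

The compounds shown leave open where a single methoxy group, a chlorine or a hydroxyl on the phenyl ring would fall. They also leave open whether an aryl group carrying an amine would join the lower or the higher pair.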